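One amide substituent changed on a compound at the limit

A few compounds are considered here, and "the series" means these few. Any claim that something is new, unique, unknown or untested is made for them only; others in the source may bear on it.

Compound 1 `COc1cccc(OC)c1C(=O)Nc1c[nH]nc1C(=O)NCc1ccccn1`: > 50000 nM (a limit)
Compound 2 `CO[C@H]1CC[C@H](NC(=O)c2n[nH]cc2NC(=O)c2ccc(F)cc2F)CC1`: 11000 nM

In an ADME assay on MRC5 cells (Homo sapiens) for inhibition, with a stated time of 72 h (on this read-out lower numbers stand for an effect already at smaller amounts and higher numbers for an effect only at larger amounts of compound), compound 1 gives > 50000 nM, which is a limit of the assay and not a number. So far, compound 2 alone has a true number, at 11000 nM.

Compound 3 `COc1cccc(OC)c1C(=O)Nc1c[nH]nc1C(=O)Nc1ccccc1` has not yet been measured. It differs from compound 1 by phenyl in place of (pyridin-2-yl)methyl on an amide-type nitrogen, with phenyl in place of (pyridin-2-yl)methyl on an amide-type nitrogen. Going by the values given here, no measured step shows what this change does, so any forecast is uncertain. In this assay a modest shift toward smaller amounts is expected, and another limit reading would be no surprise. The expected at least 2.0-fold lower number from compound 1 to compound 3 (0.30 log units; that floor lies within the scatter) is small. For compound 3 the estimate is 25000 nM, with an expected range of 8000 nM to 50000 nM.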

Compound 3, half-maximal effective concentration: > 50000 nM
Compound 3 ended at the assay's limit; the forecaster's own chance of this, stated with the estimate: 35%; at least 2.0-fold (0.30 log units) between middle value and limit.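

Compound 1 and compound 3 both end at a limit of the assay rather than at a number, so no step can be read between them: the limit of > 50000 nM in this assay, at which 2 of the 3 values shown sit. The compounds shown leave open what phenyl in place of (pyridin-2-yl)methyl on an amide-type nitrogen does in this assay.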